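Swapping a pyridine for a benzene on a thiourea

The source may report more compounds than this note shows. Statements on the series, on what has been measured and on what is new or still open speak of the compounds shown alone.

Three thioureas have been tested in an assay on membranes from brain for binding affinity to Lysophosphatidylserine lipase ABHD12 (Mus musculus), read by fluorescence, with a stated time of 20 min, tested at 10 uM; on this read-out higher numbers stand for a stronger effect at the one concentration tested and lower numbers for a weaker effect. Compound 1, with the structure `FC(F)(F)c1cnc(N2CCC(NC(=S)Nc3cccnc3)CC2)c(Cl)c1`, gives 96% in this assay, the highest of the three numbers. Compound 3, `FC(F)(F)c1cnc(NCCCCCCNC(=S)Nc2cccnc2)c(Cl)c1`, reaches 70% in this assay, a figure beyond the scatter below that of compound 1. Compound 2, `FC(F)(F)c1cnc(N2CCC(NC(=S)Nc3cccnc3)C2)c(Cl)c1`, shows 12% in this assay, far below both. These comparisons say how the linker between the two aromatic ends matters, but none of them touches the thiourea-bound ring itself.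

Compound 4, `FC(F)(F)c1cnc(N2CCC(NC(=S)Nc3ccccc3)CC2)c(Cl)c1`, is built from compound 1 by the change (phenyl in place of pyridin-3-yl on an amide-type nitrogen). For the measured compounds named here, no measured pair in this set shows the effect of such a change, so no direct precedent exists. Because compound 1 sits at 96%, a value near the top of what a single-concentration read-out can report, the expected step of a number 8 percentage points lower from compound 1 to compound 4 (within the scatter) is small and, if anything, downward, likely within the scatter. Compound 4 is therefore estimated at 88%, with a plausible range from 60% to 98%.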

Compound 4, a percentage reported as inhibition, at one concentration (the size of the read-out at that concentration, not a potency): 96%
Compound 4: middle estimate off by 8 percentage points, on the low side; the measured number falls inside the stated range.
By their numbers in this assay, from the lowest: compound 2; then compound 3; then compounds 1 and 4 (each within the scatter of the next).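

In this assay, putting phenyl in place of pyridin-3-yl on an amide-type nitrogen gives no change at the digits printed from compound 1 to compound 4 (within the scatter). For the compounds shown here, the earlier compounds varied only the linker, and this pair is the first look at the ring on the thiourea: the ring nitrogen and the hydrogen-bond acceptor it counts as can be lost without any visible cost to the reading at this one concentration, with compound 4 at 96% in this read-out. Nothing measured here explains why the two rings read alike.

A single concentration this close to the top of the percentage scale cannot show whether compound 1 and compound 4 differ in potency. As far as these compounds go, it also remains open how far this tolerance extends, for example to cyclohexyl, to a phenyl carrying a carboxylic acid or an amine, or to a longer chain on that nitrogen.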